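The source may report more compounds than this note shows. Statements on the series, on what has been measured and on what is new or still open speak of the compounds shown alone.

Of the compounds shown here, three have so far been measured in a functional assay for inhibition, with a stated time of 5 min, tested at 1 mM; a higher number here means more inhibition at the concentration tested (going by the name of the read-out), a lower number less inhibition. Compound 1 `COc1cc(/C(Cl)=C/C=C(\C#N)C(=O)c2c[nH]c3ccccc23)cc(OC)c1OC` gives 59.1%. Compound 2 `COc1ccc(/C(Cl)=C/C=C(\C#N)C(=O)c2c(C)[nH]c3ccccc23)cc1` gives 63.1% in this assay. Compound 3 `COc1ccc(/C(Cl)=C/C=C(\C#N)C(=O)c2c[nH]c3ccccc23)cc1OC` gives 63.6% in this assay, the highest of the three numbers shown, although its gap to compound 2 and its gap to compound 1 both fall within the scatter. Within the data shown here, the only step between compounds that differ in a single place is a number 4.5 percentage points higher from compound 1 to compound 3 (within the scatter), itself within the scatter.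

Compound 4 `COc1ccc(/C(Cl)=C/C=C(\C#N)C(=O)c2c(C)[nH]c3ccccc23)cc1OC` differs from compound 3 by methyl in place of hydrogen on an aromatic carbon. Among the measured compounds shown here, no measured step isolates this change. Compound 2 carries the same methyl together with a single methoxy group and gives 63.1%, while compound 3 gives 63.6%; these two values lie within the scatter of each other. Nothing seen so far therefore points to a step beyond the scatter in this assay. Compound 4 is thus expected to give 63%, with a range from 52% to 74%. The expected step is a number 0.6 percentage points lower from compound 3 to compound 4 (within the scatter), within the usual scatter.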

Compound 4, a percentage reported as inhibition, at one concentration (the size of the read-out at that concentration, not a potency): 66.4%
Estimate against measurement, compound 4: 3.4 percentage points below; the range from low to high includes it.
By their numbers in this assay, from the lowest: compounds 1, 2, 3 and 4 (each within the scatter of the next).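

In this assay, methyl in place of hydrogen on the aromatic carbon next to the ring nitrogen now has a step of its own, a number 2.8 percentage points higher from compound 3 to compound 4 (within the scatter), so no effect of this change can be read at this position. A further methoxy group, read with that methyl present, gives a number 3.3 percentage points higher from compound 2 to compound 4 (within the scatter) and is likewise no readable change. This methoxy change can now be compared on two cores, and the two steps agree within the scatter: the same change on two cores in this assay, a number 4.5 percentage points higher (within the scatter) from compound 1 to compound 3 and a number 3.3 percentage points lower (within the scatter) from compound 4 to compound 2, 7.8 percentage points apart, within the scatter of two such steps.

What an ethyl, a longer chain, an amine or a carboxylic acid would do at this position stays open, as the compounds shown carry only hydrogen or methyl there. Since every step shown lies within the scatter, it also stays open which changes to the shared core would move inhibition at all.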